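Ketone-Pyrazolone Analogues Against an Alkylation Repair Dioxygenase

This account rests on a few compounds, and the source may have more. Where it says the series, first, only, none or still open, it means among the compounds named here.

Compound 1 `Cc1[nH]n(-c2ccccn2)c(=O)c1C` gives, in an assay on isolated protein for inhibition of alpha-ketoglutarate-dependent dioxygenase alkB homolog 3 (Homo sapiens), read by polymerase chain reaction, with a stated time of 1 h (a higher number here means a weaker inhibitor, a lower number a stronger inhibitor), only a limit of the assay: compound 1 reads > 10000 nM.
Compound 2 `COC(=O)Cc1c(C)[nH]n(-c2nc3ccccc3[nH]2)c1=O` gives in this assay a number: compound 2 reads 4300 nM.
Compound 3 `Cc1[nH]n(-c2nc3c(C)cccc3[nH]2)c(=O)c1C` gives in this assay only a limit of the assay: compound 3 reads > 10000 nM.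

Among the three measured compounds, compound 2 is the only one for which this assay returns a number at all; the two others rest at the limit of > 10000 nM in this assay, at which 2 of the 3 values shown sit. Compound 2 therefore stands alone as the sole point on which any expectation can be anchored, and it stands well away from the potent end of the scale.

Compound 4 `Cc1[nH]n(-c2nc3ccccc3[nH]2)c(=O)c1Cc1ccc(Cl)cc1` differs from compound 2 in one place: 4-chlorophenyl in place of methoxycarbonyl on a saturated chain carbon bound to an aromatic carbon. Within the data shown here, no measured pair in this set makes a comparable change, so nothing here shows how much this exchange may shift inhibition.

For compound 4 the expectation is a modest gain over compound 2, with a step of a 1.7-fold lower number from compound 2 to compound 4 (0.24 log units; within the scatter) in this assay, though a step of this size barely exceeds the usual scatter. The value of compound 4 in this assay is estimated at 2500 nM, within a range from 500 nM to 12000 nM.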

Compound 4, half-maximal inhibitory concentration: > 10000 nM
Compound 4 was reported as a limit; the forecaster's own chance of this, stated with the estimate: 30%; at least 4.0-fold (0.60 log units) between middle value and limit.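

In this assay, among these compounds, 4-chlorophenyl in place of methoxycarbonyl on a saturated chain carbon bound to an aromatic carbon gives an at least 2.3-fold higher number from compound 2 to compound 4 (0.36 log units; beyond the scatter), the first comparison in this set that can be read at all. Compound 4 reads > 10000 nM, which is a limit of the assay. This place therefore does not accept every group alike, and the exchange takes away the only number the set had, leaving compound 2 alone with a measured value while the other compounds share one limit: the limit of > 10000 nM in this assay, at which 3 of the 4 values shown sit.

How much inhibition is lost cannot be told from a limit, and a single exchange does not show whether the methoxycarbonyl group itself supports the inhibition of compound 2 or whether the 4-chlorophenyl group simply fails to. A carboxylic acid or a primary amide in place of methoxycarbonyl at the same place, or a longer chain carrying the same ester, would show how closely the value of compound 2 depends on this group, and whether any number better than 4300 nM can be reached from here.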